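Amide variation on the shared indazolyl-azaindole series

This account rests on a few compounds, and the source may have more. Where it says the series, first, only, none or still open, it means among the compounds named here.

Measured compounds:
compound 1 `CN(C(=O)c1ccc(Cl)cc1)c1ccc2[nH]c(-c3n[nH]c4ccccc34)cc2n1` — 630 nM
compound 2 `CN(C(=O)c1ccc([N+](=O)[O-])cc1)c1ccc2[nH]c(-c3n[nH]c4ccccc34)cc2n1` — 20200 nM

Compound 2 `CN(C(=O)c1ccc([N+](=O)[O-])cc1)c1ccc2[nH]c(-c3n[nH]c4ccccc34)cc2n1` gives the highest number of the two in a functional assay on KB cells (Homo sapiens) for antiproliferative activity, read by MTT assay, with a stated time of 72 h (on this read-out higher numbers stand for weaker inhibition and lower numbers for stronger inhibition), with 20200 nM; its nearest neighbour is compound 1 `CN(C(=O)c1ccc(Cl)cc1)c1ccc2[nH]c(-c3n[nH]c4ccccc34)cc2n1`, which gives 630 nM in this assay. Going by the values given here, the one measured step, a 32-fold higher number from compound 1 to compound 2 (1.51 log units; beyond the scatter), is large and beyond the scatter; it involves nitro in place of chloro on an aromatic carbon.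

Compound 3 `CN(C(=O)c1ccco1)c1ccc2[nH]c(-c3n[nH]c4ccccc34)cc2n1` is not yet measured. It differs from compound 2 by furan-2-yl in place of 4-nitrophenyl on a carbonyl carbon. Among the compounds with values here, the step of a 32-fold higher number from compound 1 to compound 2 (1.51 log units; beyond the scatter) bears on it only in part: it shows the cost of bringing the nitro group in, and compound 3 takes that group out again, but it replaces the whole 4-nitrophenyl rather than the nitro alone, and no measured step covers a furan-2-yl at this place. The expectation is therefore a clearly lower number than compound 2, though not necessarily reaching compound 1. For compound 3 the expected value in this assay is 2500 nM, with a range of 600 nM to 10000 nM, an estimated step of an 8.1-fold lower number from compound 2 to compound 3 (0.91 log units; beyond the scatter).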

Compound 3, half-maximal inhibitory concentration: 19400 nM
Compound 3: middle estimate off by 7.8-fold (0.89 log units), on the low side, and the stated range ends below it.
By their numbers in this assay, from the lowest: compound 1; then compounds 3 and 2 (each within the scatter of the next).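

In this assay, furan-2-yl in place of 4-nitrophenyl on the carbonyl carbon gives a 1.0-fold lower number from compound 2 to compound 3 (0.02 log units; within the scatter) and so leaves the number where it stood, even though the nitro group has gone and the ring has changed. Set against the 4-chlorophenyl amide, the same furan-2-yl gives a 31-fold higher number from compound 1 to compound 3 (1.49 log units; beyond the scatter), so the large gap first seen with the nitro group is not specific to it: among these three amides, only the 4-chlorophenyl of compound 1 holds the low number, while two quite different groups, 4-nitrophenyl and furan-2-yl, stand level. No measured property of these groups accompanies the result, and the reason for this pattern stays unexplained.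

The compounds shown leave open whether compound 1 owes its low number to the chloro substituent or to the phenyl ring itself, a question that an unsubstituted phenyl or a 4-fluorophenyl at this place would address. They also leave open how the position responds to a 4-aminophenyl, a 4-carboxyphenyl or a saturated group such as cyclohexyl on the carbonyl carbon.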